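A new group on the nitrogen of compound 3

The compounds below may be only part of what the source reports. "The series", "measured", "known", "first", "only" and "open" are said of these compounds alone.

Compound 1 `CCOC(=O)C(=O)CC(=O)/C=C/c1cn(-c2ccc(Cl)cc2)c2ccccc12` – "not determined" (no result reported)
Compound 2 `CCOC(=O)C(=O)CC(=O)/C=C/c1cn(Cc2ccc(F)cc2)c2ccccc12` – "not determined" (no result reported)
Compound 3 `O=C(/C=C/c1cn(-c2ccc(Cl)cc2)c2ccccc12)CC(=O)C(=O)O` – > 40000 nM (a limit)

In an ADME assay on HeLa cells (Homo sapiens) for inhibition, read by MTT assay, with a stated time of 48 h (a lower number here means a stronger inhibitor, a higher number a weaker inhibitor), compound 3 gives > 40000 nM as its result, and this is a limit and not a number. Among the compounds with values here, compound 1 and compound 2 have no result, so no comparison between measured compounds is possible, and no measured step shows how much a change at any position matters.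

Compound 4 `COc1ccc(Cn2cc(/C=C/C(=O)CC(=O)C(=O)O)c3ccccc32)cc1` carries 4-methoxybenzyl in place of 4-chlorophenyl on an aromatic nitrogen and is otherwise the same as compound 3. This is the only difference, and the data give no measured guide to its effect. The expectation therefore rests on compound 3 alone, with its limit of > 40000 nM as the only anchor. The estimated change is a number no higher from compound 3 to compound 4 (the limit leaves the size open) in this assay, and no shift beyond the usual scatter is expected in either direction. A report of only a limit is also quite likely. For compound 4 the expected value is 40000 nM, with an estimated range from 15000 nM to 80000 nM as the likely span.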

Compound 4, half-maximal inhibitory concentration: > 40000 nM
Compound 4 gave a limit, no number; the forecaster's own chance of this, stated with the estimate: 65%; the middle value sits exactly at the limit.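

Compound 3 and compound 4 both give a limit and not a number, so no step between them can be read: the limit of > 40000 nM in this assay, at which 2 of the 4 values shown sit.

The compounds shown leave open how strongly either one inhibits in this assay, and whether 4-methoxybenzyl in place of 4-chlorophenyl on the aromatic nitrogen changes that result.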